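Removing the Hydroxy Group from a Brominated Lactone

A few compounds are considered here, and "the series" means these few. Any claim that something is new, unique, unknown or untested is made for them only; others in the source may bear on it.

compound 1 `CCC[C@@H](OC(C)=O)C1=C(Br)C(=C(Br)Br)OC1=O`: < 0.1 ug/mL
compound 2 `CCC[C@@H](O)C1=C(Br)C(=C(Br)Br)OC1=O`: 0.3 ug/mL

Of the compounds shown here, two of the shared core have been tested in a functional assay on ZR-75-1 cells (Homo sapiens) for cytotoxicity; a higher number here means that more compound is needed for the effect, a lower number that less compound is needed. Compound 1 `CCC[C@@H](OC(C)=O)C1=C(Br)C(=C(Br)Br)OC1=O` reaches only the limit of the assay, < 0.1 ug/mL, so no number is known for it (the limit of < 0.1 ug/mL in this assay, at which 1 of the 2 values shown sits). Going by the values given here, compound 2 `CCC[C@@H](O)C1=C(Br)C(=C(Br)Br)OC1=O` gives 0.3 ug/mL, the only true number among the two values shown. Among the compounds with values here, the step of an at least 3.0-fold higher number from compound 1 to compound 2 (0.47 log units; beyond the scatter) is the only measured step.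

Compound 3 `CCCCC1=C(Br)C(=C(Br)Br)OC1=O` differs from compound 2 by hydrogen in place of hydroxy on a saturated chain carbon bound to a double-bonded ring carbon and a saturated chain carbon. Within the data shown here, no measured step covers this particular change; the step of an at least 3.0-fold higher number from compound 1 to compound 2 (0.47 log units; beyond the scatter) concerns a different replacement and offers no direct guide. The expectation for this assay is therefore a step of no change at the digits printed from compound 2 to compound 3 (within the scatter), no more than modest in size. Compound 3 is expected to give 0.3 ug/mL in this assay, with a range from 0.1 ug/mL to 1 ug/mL.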

Compound 3, concentration for half-maximal effect: 8.6 ug/mL
Compound 3: the middle estimate sits 29-fold (1.46 log units) below what was measured; the measured number lies above the stated range.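

In this assay, the earlier step only changed what sits on the oxygen of this saturated chain carbon, whereas here the oxygen itself is gone, and the number rises sharply: a 29-fold higher number from compound 2 to compound 3 (1.46 log units; beyond the scatter). Replacing the whole acetoxy group with hydrogen gives an even wider gap on paper, an at least 86-fold higher number from compound 1 to compound 3 (1.93 log units; beyond the scatter). That second step is open-ended, as compound 1 stands at a limit rather than at a true number: the limit of < 0.1 ug/mL in this assay, at which 1 of the 3 values shown sits.

The compounds shown do not say why losing this oxygen has so large an effect, or whether another group on the same carbon, such as an amine or a methoxy group, would keep the number low. They also leave open how a longer chain in place of the 1-hydroxybutyl group would behave.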